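Compound 2 and the allylcarbamoyl step in an MCF7 assay

This account rests on a few compounds, and the source may have more. Where it says the series, first, only, none or still open, it means among the compounds named here.

In a functional assay on MCF7 cells (Homo sapiens) for inhibition, read by radiometric assay and XTT assay (on this read-out higher numbers stand for weaker inhibition and lower numbers for stronger inhibition), compound 1 (`CCCCCC[C@@]1(C)SC(=O)C=C1OC`) gives 9.4 ug/mL, compound 2 (`CCCCCCCC[C@@]1(C)SC(=O)C=C1OC`) gives 16.4 ug/mL and compound 3 (`C=CCOC1=CC(=O)S[C@]1(C)CCCCCC`) gives 9 ug/mL. Compound 2 therefore stands within the usual scatter of both other compounds, and the three numbers show no order that can be trusted.

The next compound is compound 4 (`C=CCNC(=O)COC1=CC(=O)S[C@]1(C)CCCCCCCC`), which differs from compound 2 as follows: allylcarbamoyl in place of hydrogen on a saturated chain carbon bound to an oxygen on an unsaturated carbon. The same difference, cut one bond further out, reads methyl to (allylcarbamoyl)methyl.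

Two measured steps can be weighed against this change. The closer one falls at the same place, where vinyl replaces hydrogen, and it is small: a 1.0-fold lower number from compound 1 to compound 3 (0.02 log units; within the scatter). The other, a 1.7-fold higher number from compound 1 to compound 2 (0.24 log units; within the scatter), concerns the chain that compound 4 shares with compound 2, so it bears on the change only indirectly. For the measured compounds named here, neither step leaves the scatter, yet no measured compound carries the amide of the entering group, so the evidence is thin.

No step beyond the scatter is therefore expected, and the estimated step is a 1.1-fold lower number from compound 2 to compound 4 (0.04 log units; within the scatter). For compound 4 the expected value is 15 ug/mL, with an estimated range from 6 ug/mL to 40 ug/mL.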

Compound 4, half-maximal inhibitory concentration: 12.1 ug/mL
Compound 4: middle estimate off by 1.2-fold (0.09 log units), on the high side, and the stated range covers the measured number.
By their numbers in this assay, from the lowest: compounds 3, 1, 4 and 2 (each within the scatter of the next).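

For the compounds shown here, the place on the saturated chain carbon bound to an oxygen on an unsaturated carbon had so far been probed only with vinyl, in the step of a 1.0-fold lower number from compound 1 to compound 3 (0.02 log units; within the scatter). Compound 4 extends this to a larger group, allylcarbamoyl, with 6 heavy atoms, including a nitrogen, and one hydrogen-bond donor, and in this assay the step reads a 1.4-fold lower number from compound 2 to compound 4 (0.13 log units; within the scatter), so adding the amide still produces no change that can be told from scatter at this place. No measurement shown offers an explanation for this result.

The compounds shown leave open whether allylcarbamoyl would behave in the same way on the shorter chain of compound 1, as the group appears here only on the chain of compound 2. They also leave open whether a carboxylic acid or a primary amine at this place, or a tertiary amide without the amide hydrogen, would produce a step beyond the scatter.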